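Dimethylamino in place of methoxy: working notes

The source may hold more compounds than are shown below. What is called first, only, known or untested is meant among the compounds shown, and "the series" means these compounds.

Measured in a functional assay on HeLa cells (Homo sapiens) for inhibition; on this read-out lower numbers stand for stronger inhibition and higher numbers for weaker inhibition:
- Compound 1 `COc1cc(/C=C/c2ccc3ccccc3c2)cc([N+](=O)[O-])c1OC`: 3200 nM
- Compound 2 `COc1c([N+](=O)[O-])cc(/C=C/c2ccc3ccccc3c2)cc1[N+](=O)[O-]`: > 5000 nM (a limit)

The value of compound 2 in this assay is > 5000 nM, which is a limit and not a number. Compound 3 `CN(C)c1c([N+](=O)[O-])cc(/C=C/c2ccc3ccccc3c2)cc1[N+](=O)[O-]` carries dimethylamino in place of methoxy on an aromatic carbon, ortho to two nitro groups: dimethylamino in place of methoxy on an aromatic carbon. Among the measured compounds shown here, the only measured step, an at least 1.5-fold higher number from compound 1 to compound 2 (0.19 log units; that floor lies within the scatter), is a different replacement, so it gives no size for this one. No step beyond the scatter is expected in this assay: a step that the limit leaves unreadable from compound 2 to compound 3. For compound 3 the estimated value is 5500 nM, with an expected range of 2000 nM to 15000 nM.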

Compound 3, half-maximal inhibitory concentration: > 5000 nM
Compound 3: no number, only a limit (the forecaster's own chance of this, stated with the estimate: 65%); the middle value does not contradict the limit.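

Compound 2 and compound 3 both give only a limit in this assay, so no step between them can be read: the limit of > 5000 nM in this assay, at which 2 of the 3 values shown sit.

The compounds shown leave open whether dimethylamino and methoxy differ at all on the shared core.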